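This account rests on a few compounds, and the source may have more. Where it says the series, first, only, none or still open, it means among the compounds named here.

Working notes on the series. In an ADME assay on HeLa cells (Homo sapiens) for cytotoxicity, read by resazurin assay, with a stated time of 2 days (a higher number here means a weaker inhibitor, a lower number a stronger inhibitor), compound 1 `Cc1ccc(/C=C/c2ncc([N+](=O)[O-])n2C)cc1` gives > 100000 nM, which is a limit of the assay and not a number. Compound 2 `Cn1c([N+](=O)[O-])cnc1/C=C/c1ccccc1Br` gives 72400 nM. Compound 3 `Cn1c([N+](=O)[O-])cnc1/C=C/c1ccc(Br)cc1` gives 72400 nM, level with compound 2 at the digits reported.

Compound 4 `CCOC(OCC)c1ccc(/C=C/c2ncc([N+](=O)[O-])n2C)cc1` is the next entry, with diethoxymethyl in place of bromo on an aromatic carbon.

For the measured compounds named here, the one measured step at a comparable place is an at least 1.3-fold lower number from compound 1 to compound 3 (0.14 log units; that floor lies within the scatter). Going by the values given here, it swaps bromo and methyl only, and no measured compound carries a group as large as diethoxymethyl, so the evidence for this change is thin. Since that step does not clearly leave the scatter, the expectation starts from compound 3 at 72400 nM, with no step beyond the scatter expected in this assay and no firm direction.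

The expected step is a 1.2-fold lower number from compound 3 to compound 4 (0.08 log units; within the scatter), an estimate that stays within the scatter. For compound 4 the estimated value is 60000 nM, with an expected range of 30000 nM to 100000 nM.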

Compound 4, half-maximal inhibitory concentration: 97700 nM
Beside the measured number, compound 4's estimate is 1.6-fold (0.21 log units) below it; the measured number falls inside the stated range.
By their numbers in this assay, from the lowest: compounds 2, 3 and 4 (each within the scatter of the next). At a limit, above all of these: compound 1.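

In this assay the exchange of bromo for diethoxymethyl gives a 1.3-fold higher number from compound 3 to compound 4 (0.13 log units; within the scatter) and so stays within the scatter. Until now this place, on an aromatic carbon para to a large group, had shown only methyl and bromo; the much larger diethoxymethyl shows no step beyond the scatter from bromo, so group size alone has not yet separated the compounds here. For the compounds shown here, the comparison with methyl gives an at least 1.0-fold lower number from compound 1 to compound 4 (0.01 log units; that floor lies within the scatter) but fixes no true size of step, since compound 1 stands at a limit of the assay and not at a number: the limit of > 100000 nM in this assay, at which 1 of the 4 values shown sits.

Going by these compounds alone, the series so far has no group at this place that gives a step clearly beyond the scatter. As far as these compounds go, whether an amine or a carboxylic acid on this aromatic carbon would do so remains open.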